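Ester-bearing amide side chains on the shared core

The source may report more compounds than this note shows. Statements on the series, on what has been measured and on what is new or still open speak of the compounds shown alone.

Compound 1 `C=CCN(C)C(=O)c1ccc(C(CC)(CC)c2ccc(OCCC(O)(CC)CC)c(C)c2)n1CC` gives > 10000 nM in an assay on cells for agonist activity at vitamin D3 receptor (Homo sapiens), with a stated time of 96 h (on this read-out higher numbers stand for an effect only at larger amounts of compound and lower numbers for an effect already at smaller amounts), a limit of the assay. Compound 2 `C#CC(C)OC(=O)c1ccc(C(CC)(CC)c2ccc(OCCC(O)(CC)CC)c(C)c2)n1CC` gives 2650 nM in this assay. Compound 3 `CCC(C)C(NC(=O)c1ccc(C(CC)(CC)c2ccc(OCCC(O)(CC)CC)c(C)c2)n1CC)C(=O)OC` gives > 10000 nM in this assay, again a limit of the assay and not a number.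

Compound 3 thus sits at the upper edge of what this assay reports, the same edge that appears in the limit of > 10000 nM in this assay, at which 2 of the 3 values shown sit. Of the measured steps, an at least 3.7-fold higher number from compound 2 to compound 3 (0.57 log units; beyond the scatter) shows that moving from an ester to this amide with a methyl ester on the side chain pushes the read-out beyond the range of the assay, while a step that the two limits leave unreadable from compound 1 to compound 3 is left open by its two limits.

Compound 4 `CCOC(=O)C(CC(=O)OC)NC(=O)c1ccc(C(CC)(CC)c2ccc(OCCC(O)(CC)CC)c(C)c2)n1CC` carries the change (a group of 11 heavy atoms (7 carbon, 4 oxygen; no ring) in place of a group of 9 heavy atoms (7 carbon, 2 oxygen; no ring), on an amide-type nitrogen). The side chain on the amide-type nitrogen grows by two oxygens and gains an extra ester group, but remains an open chain of similar length. Among the compounds with values here, with compound 3 already at the limit, no measured step lets a reading in either direction be inferred for this change, and the nearest measured step, an at least 3.7-fold higher number from compound 2 to compound 3 (0.57 log units; beyond the scatter), speaks for high numbers in this region.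

Compound 4 is therefore expected to remain at or near the limit, with a step that the limit leaves unreadable from compound 3 to compound 4 as the estimated step, giving an estimate of 15000 nM within a range of 4000 nM to 60000 nM.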

Compound 4, half-maximal effective concentration: 21 nM
Beside the measured number, compound 4's estimate is 710-fold (2.85 log units) above it; measured number outside the range, below it.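

On the amide-type nitrogen, the side chain does not stay in a region of high numbers in this assay: replacing the group of 9 heavy atoms with the group of 11 heavy atoms, which carries an extra ester and remains an open chain, gives an at least 470-fold lower number from compound 3 to compound 4 (2.67 log units; beyond the scatter). The full group on the carbonyl carbon also separates compound 4 clearly from the other two groups, with a 130-fold lower number from compound 2 to compound 4 (2.10 log units; beyond the scatter) and an at least 470-fold lower number from compound 1 to compound 4 (2.67 log units; beyond the scatter). Amides therefore stand at both ends of the range shown, with compound 1 and compound 3 at the limit and compound 4 far from it, so the amide link alone does not fix the read-out.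

Two of these steps are only bounds and the step between the two limits cannot be read, as the upper edge of the assay hides how far those compounds lie: the limit of > 10000 nM in this assay, at which 2 of the 4 values shown sit. As far as these compounds go, it remains open whether the ethyl ester or the methyl ester accounts for the change, and whether a carboxylic acid, an amine or a longer chain on the amide-type nitrogen would keep so low a number.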